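Bromo in place of chloro on the fused ring: compound 4

The source may report more compounds than this note shows. Statements on the series, on what has been measured and on what is new or still open speak of the compounds shown alone.

The series shares one core. Compound 1 `CCC(CC)(CC(=O)Nc1cccc(OCc2ccc3cc(F)ccc3n2)c1)C(=O)O` carries a fluoro on the fused ring and gives 2 nM in a functional assay on ileum (Cavia porcellus) for antagonist activity at cysteinyl leukotriene receptor (Homo sapiens); a higher number here means a weaker inhibitor, a lower number a stronger inhibitor. Compound 2 `CCC(CC)(CC(=O)Nc1cccc(OCc2ccc3cc(F)c(F)cc3n2)c1)C(=O)O` carries an additional fluoro and gives 0.5 nM. Going by the values given here, the only single-change step measured so far is a 4.0-fold lower number from compound 1 to compound 2 (0.60 log units; beyond the scatter). Compound 3 `CCC(CC)(CC(=O)Nc1cccc(OCc2ccc3ccc(Cl)cc3n2)c1)C(=O)O` carries a chloro instead and gives 0.8 nM. Among the three numbers compound 3 stands second highest: its nearest neighbour is compound 2, separated by a gap within the scatter, so no order between the two can be stated; compound 1 lies furthest, its number higher by a gap beyond the scatter.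

Compound 4 `CCC(CC)(CC(=O)Nc1cccc(OCc2ccc3ccc(Br)cc3n2)c1)C(=O)O` differs from compound 3 by bromo in place of chloro on an aromatic carbon. Among the compounds with values here, no measured step swaps one halogen for another; the measured step concerns fluoro in place of hydrogen and offers no direct guide to a halogen swap. Without a matching precedent, the change is expected to move this assay by no more than the scatter, in no particular direction, no change at the digits printed from compound 3 to compound 4 (within the scatter). Compound 4 is therefore estimated at 0.8 nM, in the range 0.3 nM to 2 nM.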

Compound 4, half-maximal inhibitory concentration: 4 nM
Beside the measured number, compound 4's estimate is 5.0-fold (0.70 log units) below it, outside the stated range (above it).
By their numbers in this assay, from the lowest: compounds 2 and 3 (each within the scatter of the next); then compounds 1 and 4 (each within the scatter of the next).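

At this aromatic carbon, part of a fused system of two rings, the two halogens are not interchangeable: bromo in place of chloro gives a 5.0-fold higher number from compound 3 to compound 4 (0.70 log units; beyond the scatter) in this assay, a step that lies beyond the scatter. Going by these compounds alone, this is the only measured swap of one halogen for another, and it shows that such a swap alone can shift the number by a margin comparable in size to the one earlier step, a 4.0-fold lower number from compound 1 to compound 2 (0.60 log units; beyond the scatter), but in the opposite direction, although that step involves fluoro in place of hydrogen and not an exchange of halogens. No measurement at hand accounts for the difference between chloro and bromo at this carbon.

On these data alone, with only chloro and bromo compared at this carbon, two points cannot show whether the number follows any trend across the halogens, and how hydrogen or fluoro at the same carbon would compare with them remains open. Also open, as far as these compounds go, is how this carbon would respond to a group that is not a halogen, such as methyl, methoxy, trifluoromethyl or nitrile.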